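Permeability of an amide series: the step to compound 4

The compounds below may be only part of what the source reports. "The series", "measured", "known", "first", "only" and "open" are said of these compounds alone.

Measured compounds:
compound 1 `Cn1cc(-c2nc3c(-c4ccc(CNC(=O)c5ccc(C(C)(C)C)cc5)c(F)c4)ccnc3[nH]2)cn1`, 0.4 10^-6 cm/s
compound 2 `Cn1cc(-c2nc3c(-c4ccc(CNC(=O)c5nc(C6(C)CC6)no5)c(F)c4)ccnc3[nH]2)cn1`, 2.8 10^-6 cm/s
compound 3 `Cn1cc(-c2nc3c(-c4ccc(CNC(=O)c5cc(C(C)(C)C)no5)c(F)c4)ccnc3[nH]2)cn1`, 3 10^-6 cm/s

In an ADME assay on Caco-2 cells (Homo sapiens) for permeability, in the apical to basolateral direction (on this read-out higher numbers stand for higher permeability and lower numbers for lower permeability), compound 3 gives the highest of the three numbers. Its nearest neighbour is compound 2 (a 1.1-fold higher number from compound 2 to compound 3 (0.03 log units; within the scatter)), and its furthest is compound 1 (a 7.5-fold higher number from compound 1 to compound 3 (0.88 log units; beyond the scatter)).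

Compound 4 `Cn1cc(-c2nc3c(-c4ccc(CNC(=O)c5cc6c(s5)CCCC6)c(F)c4)ccnc3[nH]2)cn1` differs from compound 3 in one place: a group of 9 heavy atoms (8 carbon, 1 sulfur; one five-membered aromatic ring with 1 hetero atom, one six-membered non-aromatic ring of carbon only) in place of a group of 9 heavy atoms (7 carbon, 1 nitrogen, 1 oxygen; one five-membered aromatic ring with 2 hetero atoms), on a carbonyl carbon. Going by the values given here, no measured step covers this exact exchange. The two steps on the same carbonyl carbon frame it: a 1.1-fold higher number from compound 2 to compound 3 (0.03 log units; within the scatter), and a 7.5-fold higher number from compound 1 to compound 3 (0.88 log units; beyond the scatter). A group with a single hetero atom in its aromatic ring stands between these cases, so a modest downward step in this assay is expected, a 2.5-fold lower number from compound 3 to compound 4 (0.40 log units; beyond the scatter). Compound 4 is therefore estimated at 1.2 10^-6 cm/s, within a range of 0.4 10^-6 cm/s to 3.5 10^-6 cm/s.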

Compound 4, apparent permeability: 0.6 10^-6 cm/s
For compound 4 the middle estimate is 2.0-fold (0.30 log units) above the measured one; low and high end bracket the measured number.
By their numbers in this assay, from the lowest: compounds 1 and 4 (each within the scatter of the next); then compounds 2 and 3 (each within the scatter of the next).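

In this assay the group entering on the carbonyl carbon gives a 5.0-fold lower number from compound 3 to compound 4 (0.70 log units; beyond the scatter) and a 4.7-fold lower number from compound 2 to compound 4 (0.67 log units; beyond the scatter) while a 1.5-fold higher number from compound 1 to compound 4 (0.18 log units; within the scatter) stays within the scatter. A five-membered aromatic ring at this place is thus not enough to keep the higher numbers of compound 2 and compound 3, and among these four compounds only the groups with nitrogen and oxygen in that ring hold them. No evidence at hand accounts for this.

As far as these compounds go, the sulfur and the six-membered non-aromatic ring enter together, and their separate shares remain open. A thiophene or furan ring carrying a tert-butyl group would be needed to tell them apart.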